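The source may hold more compounds than are shown below. What is called first, only, known or untested is meant among the compounds shown, and "the series" means these compounds.

Going by the values given here, compound 2, `CCOC(=O)/C(O)=C/C(=O)c1cn(Cc2cc(F)ccc2F)c2cccc(OC)c12`, is one of three compounds measured so far in an ADME assay on MT4 cells (Homo sapiens) for cytotoxicity, read by MTT assay; on this read-out lower numbers stand for higher toxicity in this test and higher numbers for lower toxicity in this test. In this assay compound 2 gives 41200 nM, the second highest of the three numbers. Its nearest neighbour is compound 1, `COc1cccc2c1c(C(=O)/C=C(\O)C(=O)O)cn2Cc1cc(F)ccc1F`, which gives 46200 nM, and the furthest is compound 3, `COc1cccc2c1c(C(=O)/C=C(\O)C(=O)O)cn2Cc1ccc(F)cc1F`, which gives 20800 nM. The step of a 1.1-fold lower number from compound 1 to compound 2 (0.05 log units; within the scatter) lies within the scatter, while the step of a 2.2-fold lower number from compound 1 to compound 3 (0.35 log units; beyond the scatter) is modest but beyond it. Compound 4, `CCOC(=O)/C(O)=C/C(=O)c1cn(Cc2cc(F)cc(F)c2)c2cccc(OC)c12`, has not yet been measured in this assay. It differs from compound 2 in one place: 3,5-difluorophenyl in place of 2,5-difluorophenyl on a saturated chain carbon bound to an aromatic nitrogen. Among the compounds with values here, no measured step exchanges one difluorophenyl for the one that enters here; the only step that bears on changing the difluorophenyl on that carbon is a 2.2-fold lower number from compound 1 to compound 3 (0.35 log units; beyond the scatter), and the ethyl step a 1.1-fold lower number from compound 1 to compound 2 (0.05 log units; within the scatter) shows that the ester end of the chain changed little. A modest step toward a lower number, or none beyond the scatter, is therefore expected, a 1.4-fold lower number from compound 2 to compound 4 (0.14 log units; within the scatter). Compound 4 is expected to give about 30000 nM, between 12000 nM and 75000 nM.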

Compound 4, half-maximal cytotoxic concentration: 34700 nM
Estimate against measurement, compound 4: 1.2-fold (0.06 log units) below; measured number inside the range.
By their numbers in this assay, from the lowest: compounds 3, 4, 2 and 1 (each within the scatter of the next, the first and the last beyond it).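

Going by these compounds alone, on a saturated chain carbon bound to an aromatic nitrogen, compound 4 gives the first exchange of one difluorophenyl for another with the ethyl ester kept in place. In this assay the change to 3,5-difluorophenyl from 2,5-difluorophenyl stays within the scatter (a 1.2-fold lower number from compound 2 to compound 4 (0.07 log units; within the scatter)), so this exchange leaves no measurable difference between these two ethyl esters, unlike the modest step seen with the other exchange on the acid compounds (a 2.2-fold lower number from compound 1 to compound 3 (0.35 log units; beyond the scatter)). Nothing given here explains either step.

As far as these compounds go, whether 3,5-difluorophenyl would leave the number equally unmoved with the carboxylic acid of compound 1 in place of the ethyl ester remains open. So does the outcome with a different group on that carbon, such as plain phenyl, a chlorophenyl or a pyridine ring.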